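A Carboxy-Bearing Amide Group Exchanged on the Shared Core

This account rests on a few compounds, and the source may have more. Where it says the series, first, only, none or still open, it means among the compounds named here.

Values measured so far in a functional assay on MCF7 cells (Homo sapiens) for antiproliferative activity, read by MTT assay, with a stated time of 48 h; on this read-out higher numbers stand for weaker inhibition and lower numbers for stronger inhibition:
- Compound 1 `CCn1c(C(=O)NCCN(C)C)ccc1C(CC)(CC)c1ccc(OCCC(O)(CC)CC)c(C)c1` gives 430 nM
- Compound 2 `CCn1c(C(=O)N(CCC#N)CCC#N)ccc1C(CC)(CC)c1ccc(OCCC(O)(CC)CC)c(C)c1` gives > 50000 nM as a limit of the assay, not a number
- Compound 3 `CCC(C)C(NC(=O)c1ccc(C(CC)(CC)c2ccc(OCCC(O)(CC)CC)c(C)c2)n1CC)C(=O)O` gives 11300 nM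

Compound 3 has the higher of the two actual numbers in this assay, and the other belongs to compound 1, as a 26-fold higher number from compound 1 to compound 3 (1.42 log units; beyond the scatter) shows. Compound 2 has only a limit, and against that limit the record gives an at least 4.4-fold lower number from compound 2 to compound 3 (0.64 log units; beyond the scatter) as the comparison.

The next structure is compound 4 `CCn1c(C(=O)N(C)CC(=O)O)ccc1C(CC)(CC)c1ccc(OCCC(O)(CC)CC)c(C)c1`, which keeps the shared core and alters only the amide group: (carboxymethyl)(methyl)amino in place of (1-carboxy-2-methylbutyl)amino on a carbonyl carbon. Thus (carboxymethyl)(methyl)amino stands in place of (1-carboxy-2-methylbutyl)amino on a carbonyl carbon, and a carboxy group remains.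

Within the data shown here, no measured step exchanges one carboxy-bearing group for another, so the evidence is indirect. Compound 4 also lacks the 2-(dimethylamino)ethyl group of compound 1, and both departures from that group, an at least 110-fold higher number from compound 1 to compound 2 (2.06 log units; beyond the scatter) and a 26-fold higher number from compound 1 to compound 3 (1.42 log units; beyond the scatter), were large. Compound 4 is therefore expected to stay near compound 3 rather than return toward compound 1.

The expected change is small, an estimated 1.2-fold higher number from compound 3 to compound 4 (0.09 log units; within the scatter), and no shift beyond the scatter is anticipated. For compound 4 the estimated value is 14000 nM (expected range 5000 nM to 40000 nM).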

Compound 4, half-maximal inhibitory concentration: 79 nM
For compound 4 the middle estimate is 180-fold (2.25 log units) above the measured one, and the stated range ends above it.
By their numbers in this assay, from the lowest: compound 4; then compound 1; then compound 3. At a limit, above all of these: compound 2.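

The carboxy group alone does not fix a weak result in this assay, since both compounds in the step of a 140-fold lower number from compound 3 to compound 4 (2.16 log units; beyond the scatter) carry one and only the group around it differs on the carbonyl carbon. The 2-(dimethylamino)ethyl group of compound 1 is also not needed for the lowest number among these compounds, as the step of a 5.4-fold lower number from compound 1 to compound 4 (0.74 log units; beyond the scatter) goes beyond the scatter in favour of the carboxy-bearing (carboxymethyl)(methyl)amino group, which makes compound 4 the most potent of the four in this assay. Among these compounds, the step of an at least 630-fold lower number from compound 2 to compound 4 (2.80 log units; beyond the scatter) gives only a bound, since the first compound in it carries a limit of the assay and not a number: the limit of > 50000 nM in this assay, at which 1 of the 4 values shown sits.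

The exchange from compound 3 to compound 4 removes the 2-methylbutyl carbon chain and adds a methyl on the amide nitrogen in a single step, so the compounds shown do not separate these two changes. A (carboxymethyl)amino group that keeps the amide hydrogen, or a methyl ester in place of the carboxylic acid of compound 4, would be needed to tell how much of the drop belongs to each part of the group.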